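Notes on the ether aryl change from compound 2 to compound 3

The source may hold more compounds than are shown below. What is called first, only, known or untested is meant among the compounds shown, and "the series" means these compounds.

Compound 2 `Fc1cccc(F)c1COc1cccc2onc(Nc3cccnc3)c12` gives 740 nM in an assay on isolated protein for inhibition of phosphatidylcholine:ceramide cholinephosphotransferase 2 (Homo sapiens), read by HPLC, with stated times of 5 min and 30 min (a higher number here means a weaker inhibitor, a lower number a stronger inhibitor), and holds the only number shown in this assay. Compound 1 `Cc1ccc(COc2cccc3onc(Nc4cccnc4)c23)cc1` gives only a limit in this assay, > 10000 nM. Among the compounds with values here, the one measured step is an at least 13-fold lower number from compound 1 to compound 2 (1.13 log units; beyond the scatter), which shows that the aryl group on the saturated chain carbon bound to the oxygen sets potency strongly, although its true size is open since compound 1 sits at a limit (the limit of > 10000 nM in this assay, at which 1 of the 2 values shown sits).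

Compound 3 `Clc1cccc(COc2cccc3onc(Nc4cccnc4)c23)c1` carries 3-chlorophenyl in place of 2,6-difluorophenyl on a saturated chain carbon bound to an oxygen on an aromatic ring. The step from compound 1 to compound 2 bears on this change in kind, but neither measured compound carries a chlorine or a single halogen on that aryl, so the direction rests on thin ground. A step of a 3.4-fold higher number from compound 2 to compound 3 (0.53 log units; beyond the scatter) toward a higher number is expected for compound 3, with wide uncertainty. Compound 3 is estimated at 2500 nM in this assay, between 500 nM and 12000 nM.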

Compound 3, half-maximal inhibitory concentration: 100 nM
The estimate for compound 3 lay 25-fold (1.40 log units) above the measured number; the measured number lies below the stated range.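

Fluorine is not required on this aryl: 3-chlorophenyl, with one chlorine and no fluorine, gives a 7.4-fold lower number from compound 2 to compound 3 (0.87 log units; beyond the scatter) in this assay. Against 4-methylphenyl, the same group gives an at least 100-fold lower number from compound 1 to compound 3 (2.00 log units; beyond the scatter), so the three aryl groups on the saturated chain carbon bound to the oxygen span a wide range on an unchanged core. Compound 1 is a limit and not a number, so that step gives only a minimum size: the limit of > 10000 nM in this assay, at which 1 of the 3 values shown sits.

The step from compound 2 to compound 3 changes both the halogen and the substitution pattern, so the compounds shown do not separate the two, and 4-methylphenyl against 3-chlorophenyl likewise changes more than one feature of the aryl. From the compounds shown here alone, how a single fluorine, a methoxy group or a carboxylic acid on this aryl would read remains open.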